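Aryl swap on the pyridine core of compound 1

The source may report more compounds than this note shows. Statements on the series, on what has been measured and on what is new or still open speak of the compounds shown alone.

Compound 1 `COc1ccc(CNC(=O)c2cc(-c3cncc(C)c3)ncc2-c2cncc(F)c2)nc1OC` gives 17000 nM in an assay on CHO cells for displacement of a labelled ligand from Orexin/Hypocretin receptor type 1 variant I408V (Homo sapiens), read by scintillation counting; a lower number here means a stronger inhibitor, a higher number a weaker inhibitor. Within the data shown here, of the two values measured so far, compound 1 stands highest; its nearest neighbour, compound 2 `COc1ccc(CNC(=O)c2cc(-c3cncc(C)c3)ccc2-c2ccccc2)nc1OC`, gives 1000 nM in this assay, and the gap between the two lies beyond the usual scatter. Among the measured compounds shown here, compound 2 differs from compound 1 in more than one place, so no single step between measured compounds is available, and the two values can only be read side by side.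

Compound 3 `COc1ccc(CNC(=O)c2cc(-c3cncc(C)c3)ncc2-c2ccccc2F)nc1OC`, not yet measured, differs from compound 1 in one place: 2-fluorophenyl in place of 5-fluoropyridin-3-yl on an aromatic carbon. For the measured compounds named here, no measured step covers this exchange. Going by the values given here, the only indirect pointer is compound 2, which also carries a carbon-only ring where compound 1 carries a pyridine ring; in this assay compound 2 gives 1000 nM. On that basis a moderate drop in the number is expected for compound 3, probably beyond the scatter but well short of the gap to compound 2, because compound 2 gives 1000 nM with a second change in its core as well. The expected step is a 3.4-fold lower number from compound 1 to compound 3 (0.53 log units; beyond the scatter). For compound 3 the estimate is 5000 nM, with a range from 1500 nM to 17000 nM.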

Compound 3, inhibition constant: 8600 nM
The estimate for compound 3 lay 1.7-fold (0.24 log units) below the measured number; the range from low to high includes it.
By their numbers in this assay, from the lowest: compound 2; then compounds 3 and 1 (each within the scatter of the next).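

In this assay, 2-fluorophenyl in place of 5-fluoropyridin-3-yl on this aromatic carbon gives a 2.0-fold lower number from compound 1 to compound 3 (0.30 log units; within the scatter), so the two groups cannot be told apart in this assay, and both compounds sit in the same range of values. Among these compounds, this is the first direct reading at this position: the ring nitrogen and the one hydrogen-bond acceptor of the leaving group can go, together with the shift from 5-fluoropyridin-3-yl to 2-fluorophenyl, with no change beyond the scatter. No measurement shown here offers an explanation for this result.

The step changes the ring atoms and the fluorine placement at once, so it cannot separate the two, and compound 2 differs from compound 1 and compound 3 in more than one place, which leaves the source of its separate value unresolved. It also remains open whether groups of a different kind at this position, such as an aminomethyl group, a carboxylic acid or a morpholine ring, would move the number beyond the scatter, as both groups shown are fluorinated six-membered aromatic rings.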